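This account rests on a few compounds, and the source may have more. Where it says the series, first, only, none or still open, it means among the compounds named here.

Compound 1 `CC(C)N1CCc2nc(C#Cc3cccc(Cl)c3)ccc2C1=O`: 100 nM
Compound 2 `CC(C)N1CCc2nc(C#Cc3ccc(Cl)cc3)ccc2C1=O`: 27100 nM

In an assay on HEK293 cells for displacement of a labelled ligand from metabotropic glutamate receptor 5 (Homo sapiens), with a stated time of 2 h (on this read-out lower numbers stand for stronger inhibition and higher numbers for weaker inhibition), compound 2 gives 27100 nM, the higher of the two numbers shown; its only neighbour is compound 1 at 100 nM. Among the measured compounds shown here, the single measured step, a 270-fold higher number from compound 1 to compound 2 (2.43 log units; beyond the scatter), shows how strongly the chlorophenyl pattern on the triple-bonded carbon governs this read-out. Compound 3 `CC(C)N1CCc2nc(C#Cc3cccs3)ccc2C1=O` carries thiophen-2-yl in place of 4-chlorophenyl on a triple-bonded carbon. That step bears directly on the same position, and since compound 2 sits at the weak end, a large move back toward the number of compound 1 is expected, though with wide uncertainty. Compound 3 is expected to give about 300 nM, between 40 nM and 3000 nM. The expected step is a 90-fold lower number from compound 2 to compound 3 (1.96 log units; beyond the scatter).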

Compound 3, inhibition constant: 1930 nM
Estimate against measurement, compound 3: 6.4-fold (0.81 log units) below; the measured number falls inside the stated range.
By their numbers in this assay, from the lowest: compound 1; then compound 3; then compound 2.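

Thiophen-2-yl on the triple-bonded carbon gives back part of what 4-chlorophenyl lost, with a 14-fold lower number from compound 2 to compound 3 (1.15 log units; beyond the scatter) as the step, but it stays short of 3-chlorophenyl, with a 19-fold higher number from compound 1 to compound 3 (1.29 log units; beyond the scatter) as the step. This position therefore does not depend on a chlorophenyl alone, since a five-membered aromatic ring with a sulfur atom holds a middle level among the three compounds. No evidence here explains these differences.

On these data alone, it remains open how a 3-methylphenyl or a pyridin-2-yl on the same carbon would compare with the 3-chlorophenyl of compound 1.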